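Dropping the Chloro Group: Expected Effect on Cell Tolerance

The source may report more compounds than this note shows. Statements on the series, on what has been measured and on what is new or still open speak of the compounds shown alone.

The shared core is carried by compound 1 `Cc1ccc(-[n+]2noc([O-])c2CN2CCN(c3cccc(Cl)c3)CC2)cc1`, which in an ADME assay on HEL cells (Homo sapiens) for cytotoxicity (a higher number here means that more compound is tolerated, a lower number that less compound is tolerated), gives 100 ug/mL. Compound 2 `Cc1ccc(-[n+]2noc([O-])c2CN2CCCCC2)cc1`, whose core bears a simpler amine, gives 100 ug/mL in this assay, level with compound 1 at the digits shown and within the usual scatter. Compound 3 `[O-]c1on[n+](-c2ccc(Cc3ccc(-[n+]4noc([O-])c4CN4CCN(c5cccc(Cl)c5)CC4)cc3)cc2)c1CN1CCN(c2cccc(Cl)c2)CC1`, built on the same motif, gives in this assay only a limit of >= 20 ug/mL, a value the assay could not resolve further; this is the limit of >= 20 ug/mL in this assay, at which 1 of the 3 values shown sits. For the measured compounds named here, no single-point step between measured compounds is available, so the two numbers for compound 1 and compound 2 show only that a change at the amine left tolerance unchanged.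

Compound 4 `Cc1ccc(-[n+]2noc([O-])c2CN2CCN(c3ccccc3)CC2)cc1` differs from compound 1 by hydrogen in place of chloro on an aromatic carbon. Going by the values given here, with no measured step to draw on, the change in this assay is expected to be none beyond the scatter, or at most a slight rise in tolerance. Compound 4 is therefore expected to give about 100 ug/mL, with a range from 50 ug/mL to 200 ug/mL. The expected step is no change at the digits printed from compound 1 to compound 4 (within the scatter).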

Compound 4, minimum cytotoxic concentration: 100 ug/mL
The estimate for compound 4 equals the measured number at the digits printed; low and high end bracket the measured number.
By their numbers in this assay, from the lowest: compounds 1, 2 and 4 (each within the scatter of the next).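

For the compounds shown here, replacing chloro with hydrogen on an aromatic carbon gives, in this assay, no change at the digits printed from compound 1 to compound 4 (within the scatter), the first reading of a change made at this position alone. Compounds 1 and 2 differ in the whole amine, so they could not show what the chlorine itself contributes to this read-out. The new pair shows that, with the rest of the structure held fixed, 3-chlorophenyl and phenyl cannot be told apart in this assay, although this rests on a single pair and sets no general rule.

The compounds shown leave open whether a methoxy group, a carboxylic acid or an amine at this same place would also leave the read-out where it stands. Nothing in the data shown accounts for the result of this change.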